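Swapping the amide aryl group in an antiproliferative series

A few compounds are considered here, and "the series" means these few. Any claim that something is new, unique, unknown or untested is made for them only; others in the source may bear on it.

Three compounds have been run in a functional assay on A875 cells (Homo sapiens) for antiproliferative activity, read by MTT assay, with a stated time of 48 h; a lower number here means a stronger inhibitor, a higher number a weaker inhibitor. Compound 1 `COc1ccccc1C(=O)Nc1nnc(SCC(=O)Nc2ccc(Br)cn2)s1` gives only a limit in this assay, > 80000 nM, which is the limit of > 80000 nM in this assay, at which 1 of the 3 values shown sits. Compound 2 `O=C(CSc1nnc(NC(=O)CCl)s1)Nc1ccc(Cl)cn1` gives 8600 nM in this assay. Compound 3 `O=C(CCl)Nc1ccc(SCC(=O)Nc2ccc(Cl)cn2)cc1` gives 98 nM in this assay, the lowest of the two numbers obtained; its nearest neighbour is compound 2, whose number sits far higher, well beyond the scatter of repeat measurements. Compound 4 `O=C(CCl)Nc1ccc(SCC(=O)Nc2ccc(Cl)cc2)cc1` has not yet been measured in this assay. It differs from compound 3 in a single place: 4-chlorophenyl in place of 5-chloropyridin-2-yl on an amide-type nitrogen. For the measured compounds named here, no measured pair among the three compounds carries the same change, so its effect cannot be read off a prior step. The author expects a small step, most likely toward a somewhat higher number, but one that may well stay within the scatter. Compound 4 is therefore expected to give about 200 nM in this assay, with a plausible range from 40 nM to 1500 nM. This estimate would correspond to a step from compound 3 to compound 4 of a 2.0-fold higher number from compound 3 to compound 4 (0.31 log units; beyond the scatter), a modest weakening at most.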

Compound 4, half-maximal inhibitory concentration: 8900 nM
The estimate for compound 4 lay 45-fold (1.65 log units) below the measured number; measured number outside the range, above it.
By their numbers in this assay, from the lowest: compound 3; then compounds 2 and 4 (each within the scatter of the next). At a limit, above all of these: compound 1.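

In this assay, for the compounds shown here, the step of a 91-fold higher number from compound 3 to compound 4 (1.96 log units; beyond the scatter) is the first that can be read between two compounds differing in one place, and it shows that the aryl group on this amide-type nitrogen is far from interchangeable: 4-chlorophenyl in place of 5-chloropyridin-2-yl costs a large share of the activity. The two groups have the same count of heavy atoms and both carry a chlorine. They differ in one ring atom, a nitrogen in 5-chloropyridin-2-yl and a carbon in 4-chlorophenyl, with one hydrogen-bond acceptor on the group that leaves and none on the group that enters. Nothing measured here bears on why the step is this large.

This single pair leaves open whether the step would be of like size on the core of compound 2, whose aryl group is also 5-chloropyridin-2-yl. Also open, as far as these compounds go, is how the activity would respond to an amine or a carboxylic acid in place of the chlorine on this ring.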